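The source may hold more compounds than are shown below. What is called first, only, known or untested is meant among the compounds shown, and "the series" means these compounds.

Measured so far:
compound 1 `O=C(OC/C(=C\c1ccccc1[N+](=O)[O-])C(=O)c1ccccc1)c1ccccc1` gives 4300 nM
compound 2 `C=C(C/C(=C\c1ccc(Cl)cc1)C(=O)c1ccccc1)C(=O)c1ccccc1` gives 6100 nM

Both numbers come from a functional assay on SW1573 cells (Homo sapiens) for inhibition, read by sulforhodamine B assay, with a stated time of 48 h; a higher number here means a weaker inhibitor of growth, a lower number a stronger inhibitor of growth. Compound 2 has the higher of the two values, but its distance from compound 1 is within the scatter, so the two compounds are not separated by this assay and no order can be read between them. Going by the values given here, no single-change step between measured compounds is available, so nothing in the data yet shows how a substituent change on the aryl ring shifts the number.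

Compound 3 `C=C(C/C(=C\c1ccc(OC)cc1)C(=O)c1ccccc1)C(=O)c1ccccc1` differs from compound 2 in one place: methoxy in place of chloro on an aromatic carbon. The change exchanges one small group on the ring for another of similar size, keeping the rest of compound 2 intact. Among the compounds with values here, with no measured pair to calibrate such a swap, the expected step from compound 2 to compound 3 in this assay is small and of uncertain direction, most likely not beyond the scatter: the expected step is a 1.1-fold higher number from compound 2 to compound 3 (0.06 log units; within the scatter).

Compound 3 is therefore expected to give about 7000 nM in this assay, with a range from 2500 nM to 20000 nM.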

Compound 3, concentration for 50% growth inhibition: 450 nM
Compound 3: middle estimate off by 16-fold (1.19 log units), on the high side; the whole stated range lies above it.
By their numbers in this assay, from the lowest: compound 3; then compounds 1 and 2 (each within the scatter of the next).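

In this assay, replacing 4-chlorophenyl with 4-methoxyphenyl gives a 14-fold lower number from compound 2 to compound 3 (1.13 log units; beyond the scatter), so the aromatic carbon para to a large group is a position where one substituent exchange can alter growth inhibition well beyond the scatter. The size of this step shows that the number depends strongly on which group occupies this place, even though the rest of compound 2 stays intact and only a small group is exchanged for another small group. No measurement at hand accounts for the difference between chloro and methoxy in this series.

A single pair cannot show whether the lower number belongs to methoxy specifically or would also appear with a hydroxyl group, an amine, or a longer chain such as ethoxy at the same position. As far as these compounds go, it also remains open whether the exchange of chloro for methoxy would produce a similar step on the core of compound 1, or whether the effect is limited to the core shared by compound 2 and compound 3.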